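Swapping a methoxymethyl for a 1-bromoethyl group

The source may report more compounds than this note shows. Statements on the series, on what has been measured and on what is new or still open speak of the compounds shown alone.

Of the compounds shown here, three sharing one core have been measured in a functional assay on KYSE-450 cells (Homo sapiens) for inhibition, read by MTT assay, with a stated time of 48 h; a higher number here means a weaker inhibitor, a lower number a stronger inhibitor. Compound 1 `COc1ccc(CN(C(=O)C=C(C)C)c2cc(OC)c(OC)c(OC)c2)cc1O` gives 280 nM, compound 2 `COc1ccc(CN(C(=O)CBr)c2cc(OC)c(OC)c(OC)c2)cc1O` gives 120 nM, and compound 3 `COCC(=O)N(Cc1ccc(OC)c(O)c1)c1cc(OC)c(OC)c(OC)c1` gives 460 nM, the highest number of the three, though a 1.6-fold higher number from compound 1 to compound 3 (0.22 log units; within the scatter) stays within scatter while a 3.8-fold higher number from compound 2 to compound 3 (0.58 log units; beyond the scatter) lies beyond it. Compound 4 `COc1ccc(CN(C(=O)C(C)Br)c2cc(OC)c(OC)c(OC)c2)cc1O` differs from compound 3 by 1-bromoethyl in place of methoxymethyl on a carbonyl carbon. The most telling step is a 3.8-fold higher number from compound 2 to compound 3 (0.58 log units; beyond the scatter), where bromo gave way to methoxy at the same carbon; a 2.3-fold lower number from compound 1 to compound 2 (0.37 log units; beyond the scatter) also favours a bromine-bearing chain. Reversing that change, compound 4 is expected to reach a lower number than compound 3, with a 3.1-fold lower number from compound 3 to compound 4 (0.49 log units; beyond the scatter). Compound 4 is therefore estimated at 150 nM, most likely between 70 nM and 350 nM.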

Compound 4, half-maximal inhibitory concentration: 160 nM
Estimate against measurement, compound 4: 1.1-fold (0.03 log units) below; low and high end bracket the measured number.
By their numbers in this assay, from the lowest: compounds 2, 4, 1 and 3 (each within the scatter of the next, the first and the last beyond it).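

Placing a methyl on the bromine-bearing carbon leaves the number indistinguishable from that of the bromomethyl chain (a 1.3-fold higher number from compound 2 to compound 4 (0.12 log units; within the scatter)), so this position tolerates 1-bromoethyl as well. Compound 4 also stays clearly ahead of the methoxymethyl chain (a 2.9-fold lower number from compound 3 to compound 4 (0.46 log units; beyond the scatter)), which shows that this preference for bromine extends beyond compound 2. Yet compound 4 cannot be separated from compound 1 (a 1.8-fold lower number from compound 1 to compound 4 (0.24 log units; within the scatter)), so the 2-methylprop-1-en-1-yl chain remains comparable. As far as these compounds go, whether a chloro or an amine at this carbon, or a longer bromine-bearing chain, would match these results remains open. Nothing shown explains why the numbers fall this way.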